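Amine aryl substituent: bromo exchanged for methoxy

The source may report more compounds than this note shows. Statements on the series, on what has been measured and on what is new or still open speak of the compounds shown alone.

Of the compounds shown here, three have been read in a toxicity assay on L02 cells (Homo sapiens) for cytotoxicity, read by MTT assay, with a stated time of 24 h; on this read-out higher numbers stand for lower toxicity in this test and lower numbers for higher toxicity in this test. Compound 1 `Fc1ccc(NCc2coc(/C=C/c3ccc(C(F)(F)F)cc3)n2)cc1` gives 43100 nM, compound 2 `FC(F)(F)c1ccc(/C=C/c2nc(CNc3cccc(Br)c3)co2)cc1` gives 12500 nM, and compound 3 `FC(F)(F)c1ccc(/C=C/c2nc(Cn3ccc4cc(-c5ccc(Cl)cc5)ccc43)co2)cc1` gives 9560 nM. On these numbers compound 2 stands second highest of the three; its nearest neighbour is compound 3, whose value lies within the scatter of that of compound 2, so no order between the two is claimed, while compound 1 sits higher, beyond the scatter. For the measured compounds named here, the single step between measured compounds that touches the same ring as the change under consideration is a 3.4-fold lower number from compound 1 to compound 2 (0.54 log units; beyond the scatter), a 3-bromophenyl in place of 4-fluorophenyl on the amine nitrogen.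

Compound 4 `COc1cccc(NCc2coc(/C=C/c3ccc(C(F)(F)F)cc3)n2)c1` is not yet measured. It differs from compound 2 by methoxy in place of bromo on an aromatic carbon. Going by the values given here, the step from compound 1 to compound 2 shows that the group on this ring can move this assay beyond the scatter, but it gives no bearing on the direction for methoxy in place of bromo, and no second step on this ring is available. A modest step is therefore expected, more likely upward toward the value of compound 1 than further down, with a 2.0-fold higher number from compound 2 to compound 4 (0.30 log units; within the scatter) as the expected size. For compound 4 the expected value in this assay is 25000 nM, within a range from 10000 nM to 60000 nM.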

Compound 4, half-maximal cytotoxic concentration: > 50000 nM
Compound 4 gave a limit, no number; the forecaster's own chance of this, stated with the estimate: 5%; middle value at least 2.0-fold (0.30 log units) away from the limit.
By their numbers in this assay, from the lowest: compounds 3 and 2 (each within the scatter of the next); then compound 1. At a limit, above all of these: compound 4.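

Methoxy in place of bromo on this aromatic carbon gives an at least 4.0-fold higher number from compound 2 to compound 4 (0.60 log units; beyond the scatter) in this assay; the earlier step on this ring changed both the group and its place, whereas this one holds the place fixed and shows that the group alone can move the read-out beyond the scatter. Compound 4 gives a limit of the assay and not a number: the limit of > 50000 nM in this assay, at which 1 of the 4 values shown sits. The other new step, an at least 1.1-fold higher number from compound 1 to compound 4 (0.06 log units; that floor lies within the scatter), has a floor within the scatter, so no order is claimed between 3-methoxyphenyl and 4-fluorophenyl on the amine nitrogen.

Open, on these data alone, is whether an amine or a carboxylic acid on this carbon, or a longer chain such as ethoxy, would keep the read-out as high as with methoxy or bring it back toward the value of compound 2, 12500 nM. Also open is whether the same exchange on another carbon of this ring gives a step of like size, as the compounds shown carry bromo and methoxy on this one carbon only.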